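An Ester Swap Tested for Antiproliferative Activity

The source may report more compounds than this note shows. Statements on the series, on what has been measured and on what is new or still open speak of the compounds shown alone.

Measured so far:
compound 1 `CC(=O)O[C@H]1CC[C@]2(C)[C@H](CC[C@@](C)(O)[C@H]2CC[C@@H]2C(C)=CC[C@H]3[C@H](CC[C@]3(C)OC(C)=O)C2(C)C)OC1(C)C` gives 26200 nM
compound 2 `CC1=CC[C@H]2[C@H](CC[C@]2(C)O)C(C)(C)[C@@H]1CC[C@H]1[C@]2(C)CC[C@H](OC(=O)c3ccncc3)C(C)(C)O[C@H]2CC[C@@]1(C)O` gives 18000 nM
compound 3 `CC(=O)O[C@H]1CC[C@]2(C)[C@H](CC[C@@](C)(O)[C@H]2CC[C@@H]2C(C)=CC[C@@H]3C(C)=CC[C@@H]3C2(C)C)OC1(C)C` gives 39200 nM

All three numbers come from a functional assay on MDA-MB-231 cells (Homo sapiens) for antiproliferative activity, read by MTT assay, with a stated time of 72 h; a lower number here means a stronger inhibitor, a higher number a weaker inhibitor. Compound 2 holds the lowest number of the three, but compound 1 sits within the usual scatter of it, so these two cannot be ranked against each other; only compound 3 stands beyond the scatter, with a higher number. Within the data shown here, none of the measured pairs differs in a single place, so no measured step shows what any one change does.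

Compound 4 `CC1=CC[C@H]2[C@H](CC[C@]2(C)O)C(C)(C)[C@@H]1CC[C@H]1[C@]2(C)CC[C@H](OC(=O)c3cccc([N+](=O)[O-])c3)C(C)(C)O[C@H]2CC[C@@]1(C)O` differs from compound 2 in one place: 3-nitrophenyl in place of pyridin-4-yl on a carbonyl carbon. Among the measured compounds shown here, nothing among the measured compounds tests this kind of exchange, so there is no measured step to lean on. The expected step, a 1.2-fold lower number from compound 2 to compound 4 (0.08 log units; within the scatter), is estimated to stay within the scatter, in no clear direction. Compound 4 is therefore expected to give about 15000 nM in this assay, with a likely range from 6000 nM to 40000 nM.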

Compound 4, half-maximal inhibitory concentration: 34700 nM
For compound 4 the middle estimate is 2.3-fold (0.36 log units) below the measured one; the range from low to high includes it.
By their numbers in this assay, from the lowest: compounds 2, 1, 4 and 3 (each within the scatter of the next, the first and the last beyond it).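

In this assay, among these compounds, the exchange of pyridin-4-yl for 3-nitrophenyl on the carbonyl carbon gives a 1.9-fold higher number from compound 2 to compound 4 (0.29 log units; within the scatter) and is the first change in this set that can be read on its own. At this ester position, then, the two aromatic groups cannot be told apart in this measurement, even though the entering group is larger and carries a nitro group on a carbon-only ring. No measurement shown here bears on why the two esters read alike.

One exchange says little about the position as a whole, and the acetate esters in compounds 1 and 3 differ from compound 2 in more than one place, so they cannot settle what the aromatic ring contributes. On these data alone, it remains open what a carboxylic acid, a primary amine or a longer alkyl chain at this position would do to the number.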